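The source may report more compounds than this note shows. Statements on the series, on what has been measured and on what is new or still open speak of the compounds shown alone.

Among the measured compounds shown here, in an ADME assay (liver) for metabolic stability, with Liver microsome (Rattus norvegicus) as the target, using microsomes (a lower number here means slower removal, a higher number faster removal of the compound), compound 1 (`c1ccc(CNc2nnc(-c3c[nH]c4ncccc34)o2)cc1`) gives 40 mL.min-1.g-1 and compound 2 (`Fc1ccc(CNc2nnc(-c3c[nH]c4ncccc34)o2)cc1`) gives 58 mL.min-1.g-1, the only other number so far, so compound 1 stands within the scatter of its sole neighbour. Compound 3 (`CC(C)[C@@H](Nc1nnc(-c2c[nH]c3ncccc23)o1)c1ccccc1`) is still unmeasured. The change from compound 1 (isopropyl in place of hydrogen on a saturated chain carbon bound to an aromatic carbon and a nitrogen on an aromatic ring) is isopropyl in place of hydrogen on a saturated chain carbon bound to an aromatic carbon and a nitrogen on an aromatic ring. For the measured compounds named here, the one measured step (a 1.5-fold higher number from compound 1 to compound 2 (0.16 log units; within the scatter)) is fluoro in place of hydrogen on an aromatic carbon, a different change at a different place, so it bears only weakly. Going by the values given here, no measured compound carries anything new on that chain carbon, so the size rests on judgement. A modest rise in this assay is expected. The expected step (a 1.6-fold higher number from compound 1 to compound 3 (0.21 log units; within the scatter)) is the working figure. Compound 3 is estimated at 65 mL.min-1.g-1 with an expected range (28 mL.min-1.g-1 to 150 mL.min-1.g-1).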

Compound 3, intrinsic clearance in microsomes: 51 mL.min-1.g-1
Beside the measured number, compound 3's estimate is 1.3-fold (0.11 log units) above it; the measured number falls inside the stated range.
By their numbers in this assay, from the lowest: compounds 1, 3 and 2 (each within the scatter of the next).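

In this assay, among the compounds shown here, this is the first reading at the saturated chain carbon bound to an aromatic carbon and a nitrogen on an aromatic ring, as the earlier step concerned only an aromatic carbon. Isopropyl in place of hydrogen at this chain carbon gives a 1.3-fold higher number from compound 1 to compound 3 (0.11 log units; within the scatter), so adding 3 heavy atoms here leaves the read-out within the scatter and shows no measurable effect of this change in this assay. No supporting data explain this result.

Still open, from the compounds shown here alone, is whether a group of another kind at this chain carbon, such as a primary amine or a carboxylic acid, would move the number beyond the scatter. It is also unknown whether a longer chain such as n-butyl would behave like isopropyl, or whether fluoro on the aromatic carbon would give the same small step alongside isopropyl.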